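Shortening the alkyne chain and adding a hydroxy group

The source may report more compounds than this note shows. Statements on the series, on what has been measured and on what is new or still open speak of the compounds shown alone.

Measured compounds:
- compound 1 `CCCCCCC#Cc1ccc(S(=O)(=O)Nc2cccc(-c3csc(NC(C)=O)n3)c2)cc1`: 12.8%
- compound 2 `CC(=O)Nc1nc(-c2cccc(NS(=O)(=O)c3ccc(Br)cc3)c2)cs1`: 19.7%
- compound 3 `CCCCC#Cc1ccc(S(=O)(=O)Nc2cccc(-c3csc(NC(C)=O)n3)c2)cc1`: 9.3%

In a functional assay on A-375 cells (Homo sapiens) for antiproliferative activity, read by trypan blue exclusion, with a stated time of 48 h, tested at 5 uM (a lower number here means a stronger effect, a higher number a weaker effect of the compound at the concentration tested), compound 3 gives the lowest number of the three. Its nearest neighbour is compound 1, reached by a number 3.5 percentage points lower from compound 1 to compound 3 (within the scatter), so the two cannot be told apart. Compound 2 lies furthest away: a number 10.4 percentage points lower from compound 2 to compound 3 (beyond the scatter).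

Compound 4 `CC(=O)Nc1nc(-c2cccc(NS(=O)(=O)c3ccc(C#CCO)cc3)c2)cs1` differs from compound 3 in one place: hydroxy in place of propyl on a saturated chain carbon bound to a triple-bonded carbon

Within the data shown here, two measured steps bear on this. Shortening the chain by two carbons, from compound 1 to compound 3, moved the number only within the scatter: a number 3.5 percentage points lower from compound 1 to compound 3 (within the scatter). Replacing bromo by the full hex-1-yn-1-yl chain, from compound 2 to compound 3, gave a modest step beyond the scatter: a number 10.4 percentage points lower from compound 2 to compound 3 (beyond the scatter). Among the measured compounds shown here, no measured compound carries a hydroxy, so the effect of that group is unknown here. Trimming the chain alone would be expected to change little, while the new hydroxy adds uncertainty in either direction. For compound 4 the expected step is therefore a number 5.7 percentage points higher from compound 3 to compound 4 (within the scatter), a small rise in the number that stays within the scatter. Compound 4 is estimated at 15%, with a range from 5% to 30%.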

Compound 4, a percentage reported as activity, at one concentration (the size of the read-out at that concentration, not a potency): 99.3%
Compound 4: the middle estimate sits 84.3 percentage points below what was measured, outside the stated range (above it).
By their numbers in this assay, from the lowest: compounds 3, 1 and 2 (each within the scatter of the next, the first and the last beyond it); then compound 4.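

In this assay, the change to the 3-hydroxyprop-1-yn-1-yl group gives a large step from each measured neighbour: a number 90 percentage points higher from compound 3 to compound 4 (beyond the scatter), a number 86.5 percentage points higher from compound 1 to compound 4 (beyond the scatter), and a number 79.6 percentage points higher from compound 2 to compound 4 (beyond the scatter). The earlier swaps on this aromatic carbon gave modest steps at most, so the position had seemed forgiving, but the triple bond alone clearly does not keep the effect at the tested concentration, since compound 4 retains it and the effect is all but gone. Nothing measured here explains this loss.

Compound 4 loses the propyl part of the chain and gains the hydroxy in a single change, so the two cannot be separated. A plain prop-1-yn-1-yl group would test the short chain alone, while a hexynyl chain ending in hydroxy or an amine in place of the hydroxy would test the end group.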